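Ether for alkyl in the amide chain, cytotoxicity unchanged

A few compounds are considered here, and "the series" means these few. Any claim that something is new, unique, unknown or untested is made for them only; others in the source may bear on it.

Compound 1 `CCCCCC(=O)Nc1cc2nc(C3CCCCC3)[nH]c2cc1N1CCCC1` was tested in an ADME assay on Vero cells (Chlorocebus sabaeus) for cytotoxicity, read by resazurin assay, with a stated time of 3 days (on this read-out lower numbers stand for stronger inhibition and higher numbers for weaker inhibition), and compound 1 gives > 100 ug/mL, which is a limit of the assay and not a number. Compound 2 `COc1ccc(C(=O)Nc2cc3nc(C4CCCCC4)[nH]c3cc2N(C)C)cc1` in this assay likewise gives > 100 ug/mL, again a limit. Compound 3 `CCCCCC(=O)Nc1cc2nc(C3CCCCC3)[nH]c2cc1N(CC)CC` has "not determined" (no result reported) in this assay. Compound 1 therefore stands where most of the shown results sit: the limit of > 100 ug/mL in this assay, at which 2 of the 3 values shown sit. Compound 4 `CCCOCC(=O)Nc1cc2nc(C3CCCCC3)[nH]c2cc1N1CCCC1` has not yet been measured; it differs from compound 1 by propoxy in place of butyl on a saturated chain carbon bound to a carbonyl carbon. Among the measured compounds shown here, no step between measured compounds is available to scale this change, so in this assay no movement beyond the scatter is expected in either direction. The expected step is a number no higher from compound 1 to compound 4 (the limit leaves the size open). Compound 4 is expected to give about 100 ug/mL in this assay, within 50 ug/mL to 200 ug/mL, and most likely to be reported again only as a limit.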

Compound 4, half-maximal inhibitory concentration: > 100 ug/mL
Compound 4: no number, only a limit (the forecaster's own chance of this, stated with the estimate: 85%); the middle value lies on the limit itself.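

In this assay compound 1 and compound 4 each give only a limit of the assay and not a number, so no step can be read between them. The compounds shown leave open whether propoxy in place of butyl shifts cytotoxicity at all, and in which direction.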